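The source may report more compounds than this note shows. Statements on the series, on what has been measured and on what is new or still open speak of the compounds shown alone.

Of the compounds shown here, three have been measured in a functional assay on HTB-54 cells (Homo sapiens) for cytotoxicity, read by MTT assay, with a stated time of 72 h; a higher number here means a weaker inhibitor of growth, a lower number a stronger inhibitor of growth. Compound 1 `CCCCC[Se]c1nc([Se]CCCCC)c2cccnc2n1` gives 60500 nM in this assay. Compound 2 `COc1ccc(CNc2nc([SeH])nc3ccccc23)cc1` gives 60900 nM in this assay. Compound 3 `CCCCC[Se]c1nc(NCc2ccc(SC)cc2)c2ccccc2n1` gives 81300 nM in this assay. Compound 3 stands alongside the other two: its number lies within the scatter of the number for compound 2 and within the scatter of the number for compound 1, so the three cannot be told apart on these data.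

Compound 4 `CSc1ccc(CNc2nc([SeH])nc3ccccc23)cc1` has not yet been measured in this assay. It differs from compound 3 in one place, (hydrogen in place of pentyl on a selenium). For the measured compounds named here, no step between two measured compounds isolates this change, since compound 2 carries hydrogen on selenium but also a different group on the benzyl ring, so only the two values of compound 2 and compound 3 can be set side by side, and they fall within the scatter of each other.

On that basis the step from compound 3 to compound 4 is expected to be small, a 1.3-fold lower number from compound 3 to compound 4 (0.10 log units; within the scatter), with no clear direction beyond the scatter. Compound 4 is estimated to give about 65000 nM in this assay, within a range from 30000 nM to 140000 nM.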

Compound 4, concentration for total growth inhibition: > 100000 nM
Compound 4: no number, only a limit; the forecaster's own chance of this, stated with the estimate: 10%; middle value at least 1.5-fold (0.18 log units) from the limit.
By their numbers in this assay, from the lowest: compounds 1, 2 and 3 (each within the scatter of the next). At a limit, above all of these: compound 4.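

In this assay compound 4 reaches only a limit and not a number, > 100000 nM, so the two steps into it give floors rather than sizes. The earlier compounds shown here offered no single-place comparison, but two are now available: hydrogen in place of pentyl on a selenium whose other neighbour is an aromatic carbon gives an at least 1.2-fold higher number from compound 3 to compound 4 (0.08 log units; that floor lies within the scatter), and methylsulfanyl in place of methoxy on an aromatic carbon gives an at least 1.6-fold higher number from compound 2 to compound 4 (0.21 log units; that floor lies within the scatter). Neither floor shows a change beyond the scatter, and neither rules out a larger one, so the effect of either change stays unsettled, while compound 4 is the only compound shown that sits at such a limit: the limit of > 100000 nM in this assay, at which 1 of the 4 values shown sits.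

The compounds shown leave open how the number would respond to a chain shorter or longer than pentyl on this selenium, or to a benzyl group there in place of the chain. They also leave open whether an amine or a carboxylic acid in place of methylsulfanyl on the benzyl ring would bring the number back within a measurable range.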